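This account rests on a few compounds, and the source may have more. Where it says the series, first, only, none or still open, it means among the compounds named here.

In a functional assay on DU-145 cells (Homo sapiens) for cytotoxicity, read by MTT assay, with a stated time of 48 h (a higher number here means a weaker inhibitor, a lower number a stronger inhibitor), compound 1 (`COc1ccc(/C=C/C(=O)/C=C/c2cc3ccccc3nc2Cl)cc1`) gives > 10000 nM, which is a limit of the assay and not a number. Compound 2 (`COc1ccc(/C=C/C(=O)/C=C/c2cc3ccccc3nc2Cl)c(OC)c1`), carrying methoxy in place of hydrogen on an aromatic carbon, gives > 10000 nM, which is also a limit. Within the data shown here, the one measured step, a step that the two limits leave unreadable from compound 1 to compound 2, therefore offers no size to carry over, and the limit of > 10000 nM in this assay, at which 2 of the 2 values shown sit, is all that the two compounds show so far. Compound 3 (`COc1ccc(/C=C/C(=O)/C=C/c2cc3ccccc3nc2Oc2ccc(Br)cc2)cc1`) alters compound 1 differently: 4-bromophenoxy in place of chloro on an aromatic carbon. In words, 4-bromophenoxy stands in place of chloro on an aromatic carbon, next to the ring nitrogen. Among the measured compounds shown here, no measured step gives a size for this change, so only a modest, uncertain move toward a stronger inhibitor is expected in this assay, and another limit remains possible. The expected change is an at least 1.4-fold lower number from compound 1 to compound 3 (0.15 log units; that floor lies within the scatter). For compound 3 the estimated value is 7000 nM, with an expected range from 1500 nM to 30000 nM.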

Compound 3, half-maximal inhibitory concentration: > 10000 nM
Compound 3 was reported as a limit; the forecaster's own chance of this, stated with the estimate: 40%; at least 1.4-fold (0.15 log units) between middle value and limit.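

In this assay compound 3 gives > 10000 nM, which is a limit of the assay. Compound 1 also sits at a limit, so the step between compound 1 and compound 3 cannot be read. The compounds shown leave open whether any of these changes alters activity, with all of them at one limit: the limit of > 10000 nM in this assay, at which 3 of the 3 values shown sit.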